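A few compounds are considered here, and "the series" means these few. Any claim that something is new, unique, unknown or untested is made for them only; others in the source may bear on it.

Within the data shown here, compound 2, whose structure is `CC(=O)OC/C(=C\C1CCCCC1)C(=O)c1ccc(Cl)cc1`, stands at the weaker end of the two numbers so far: in a functional assay on HBL-100 cells (Homo sapiens) for inhibition, read by sulforhodamine B assay, with a stated time of 48 h (a lower number here means a stronger inhibitor of growth, a higher number a weaker inhibitor of growth), compound 2 gives 31000 nM, while compound 1, `CC(=O)OC/C(=C\c1ccc(Cl)cc1Cl)C(=O)c1ccccc1`, gives 3100 nM, a gap beyond the usual scatter. Compound 3, `CC(=O)OC/C(=C\c1ccc(Cl)cc1Cl)C(=O)c1ccc(Cl)cc1`, has not yet been measured in this assay. Compound 3 differs from compound 2 by 2,4-dichlorophenyl in place of cyclohexyl on a double-bonded chain carbon bound to a double-bonded chain carbon. Among the measured compounds shown here, no single-point step between measured compounds is available, so the size of this change must be estimated. Because compound 1 gives 3100 nM while carrying the same 2,4-dichlorophenyl, compound 3 is expected to sit well below compound 2, a step from compound 2 of about a 7.8-fold lower number from compound 2 to compound 3 (0.89 log units; beyond the scatter), clearly beyond the scatter. The estimate for compound 3 in this assay is 4000 nM, with a plausible range from 1500 nM to 12000 nM.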

Compound 3, concentration for 50% growth inhibition: 3200 nM
For compound 3 the middle estimate is 1.3-fold (0.10 log units) above the measured one; measured number inside the range.
By their numbers in this assay, from the lowest: compounds 1 and 3 (each within the scatter of the next); then compound 2.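

In this assay, 2,4-dichlorophenyl in place of cyclohexyl on a double-bonded chain carbon bound to a double-bonded chain carbon gives a 9.7-fold lower number from compound 2 to compound 3 (0.99 log units; beyond the scatter), so the effect of this change can now be read directly, with the rest of the structure held constant. Chloro in place of hydrogen on an aromatic carbon gives a 1.0-fold higher number from compound 1 to compound 3 (0.01 log units; within the scatter), so this chloro does not separate the two compounds in this assay, and the step at the cyclohexyl position is not matched by this second change. No measurement shown offers an explanation for either result.

The compounds shown leave open whether the step at this position comes from the aromatic ring itself or from its two chlorines, a question that plain phenyl there would address. Going by these compounds, how a free hydroxyl or an amine in place of the acetate would read also remains open.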